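The source may hold more compounds than are shown below. What is called first, only, known or untested is meant among the compounds shown, and "the series" means these compounds.

Measured so far:
compound 1 `CC(=O)N(/N=N/c1ccc([N+](=O)[O-])cc1Br)c1ccc([N+](=O)[O-])cc1Br`: 550 nM
compound 2 `O=C(c1ccccc1)N(/N=N/c1ccc([N+](=O)[O-])cc1Br)c1ccc([N+](=O)[O-])cc1Br`: 1530 nM

In a functional assay on HeLa cells (Homo sapiens) for cytotoxicity, read by MTT assay, with a stated time of 72 h (on this read-out lower numbers stand for stronger inhibition and higher numbers for weaker inhibition), compound 2 gives 1530 nM, the highest of the two numbers recorded; the nearest is compound 1, which gives 550 nM. Going by the values given here, the only measured step is a 2.8-fold higher number from compound 1 to compound 2 (0.44 log units; beyond the scatter), phenyl in place of methyl on the carbonyl carbon, a modest change beyond the scatter.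

Compound 3 `O=C(c1ccccc1F)N(/N=N/c1ccc([N+](=O)[O-])cc1Br)c1ccc([N+](=O)[O-])cc1Br` differs from compound 2 by fluoro in place of hydrogen on an aromatic carbon of the benzoyl ring, ortho to a large group, read one bond further out as phenyl to 2-fluorophenyl. Among the compounds with values here, no measured step concerns substitution on this ring. The step from compound 1 to compound 2 swaps the whole group on the carbonyl carbon and so does not bear directly on a single fluorine added to it; it only sets the scale of what a larger change at this position produced. A one-atom change of this kind is expected to give a step within the scatter, a 1.0-fold lower number from compound 2 to compound 3 (0.01 log units; within the scatter), in no fixed direction. Compound 3 is therefore estimated at 1500 nM, with a range from 700 nM to 3500 nM.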

Compound 3, half-maximal inhibitory concentration: 1200 nM
Estimate against measurement, compound 3: 1.3-fold (0.10 log units) above, and the stated range covers the measured number.
By their numbers in this assay, from the lowest: compound 1; then compounds 3 and 2 (each within the scatter of the next).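

In this assay the only substitution on the benzoyl ring so far reads as a 1.3-fold lower number from compound 2 to compound 3 (0.11 log units; within the scatter) and so fluoro in place of hydrogen on an aromatic carbon, ortho to a large group, leaves compound 3 indistinguishable from compound 2 at this level of precision. The comparison with the smaller group on the carbonyl carbon still reads as a 2.2-fold higher number from compound 1 to compound 3 (0.34 log units; beyond the scatter) and thus a single fluorine on the phenyl ring does not remove the separation from compound 1, which now holds for two aromatic groups rather than one. Nothing measured alongside these numbers speaks to why either step has the size it does.

On these data alone, whether any substituent on this ring can move the number beyond the scatter stays open, since one small atom at one place says little about a methoxy group, an amine or a carboxylic acid, or about fluoro elsewhere on the ring. Also open, as far as these compounds go, is how a longer alkyl chain in place of methyl on the carbonyl carbon would sit relative to compound 1 and compound 2.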